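The compounds below may be only part of what the source reports. "The series", "measured", "known", "first", "only" and "open" are said of these compounds alone.

Measured compounds and their values in a functional assay on PC-3 cells (Homo sapiens) for cytotoxicity, read by MTT assay, with a stated time of 72 h; on this read-out higher numbers stand for weaker inhibition and lower numbers for stronger inhibition:
- compound 1 `COc1cc(-c2cncc(N[C@@H](C)c3ccccc3)n2)ccc1O`: 10000 nM
- compound 2 `CC[C@H](Nc1cncc(-c2ccc(O)c(OC)c2)n1)c1ccccc1`: 10000 nM
- compound 3 `CCCC(Nc1cncc(-c2ccc(O)c(OC)c2)n1)c1ccc(F)cc1`: "not determined" (no result reported)

Compound 3 stands without a number in this assay; nothing measured places it on the scale. Its nearest measured relatives are compound 1 and compound 2, both of which give the same reading in this assay, so the step of no change at the digits printed from compound 1 to compound 2 (within the scatter) shows that lengthening the saturated chain at the carbon bearing the aromatic amine does not move the read-out.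

Compound 4 `CCCC(Nc1cncc(-c2ccc(O)c(OC)c2)n1)c1cccnc1` differs from compound 3 in one place: pyridin-3-yl in place of 4-fluorophenyl on a saturated chain carbon bound to a nitrogen on an aromatic ring and a saturated chain carbon. Within the data shown here, no measured step covers an exchange of this kind; the only step available, no change at the digits printed from compound 1 to compound 2 (within the scatter), touches the same chain carbon but alters the chain, not the aryl group, and it was flat. Among the measured compounds shown here, with no change so far moving the read-out beyond the scatter, and no data on the aryl exchange itself, the expectation for compound 4 in this assay is a value in the same region as compound 1 and compound 2, with a wide range to reflect the absent step.

Compound 4 is therefore estimated at 10000 nM, expected to fall between 3000 nM and 30000 nM.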

Compound 4, half-maximal inhibitory concentration: 300 nM
For compound 4 the middle estimate is 33-fold (1.52 log units) above the measured one; measured number below the stated range.
By their numbers in this assay, from the lowest: compound 4; then compounds 1 and 2 (each within the scatter of the next).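

No new step can be read in this assay: compound 3 has no number to set against compound 4 at 300 nM. No evidence at hand bears on this result. Going by these compounds, whether pyridin-3-yl in place of 4-fluorophenyl itself moves the read-out stays open.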